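Chloro to methyl on the core of compound 2

This account rests on a few compounds, and the source may have more. Where it says the series, first, only, none or still open, it means among the compounds named here.

In an ADME assay on HeLa cells (Homo sapiens) for inhibition, read by MTT assay, with a stated time of 72 h (on this read-out lower numbers stand for stronger inhibition of growth and higher numbers for weaker inhibition of growth), compound 2 `O=C(CC(=O)c1cc(Cl)ccc1O)c1cc2ccccc2s1` gives 4.42 ug/mL, the lowest of the two numbers shown. The nearest of them belongs to compound 1 `Cc1ccc2oc(-c3cc4ccccc4s3)cc(=O)c2c1`, which in this assay gives 15.6 ug/mL. Compound 3 `Cc1cc(O)c(C(=O)CC(=O)c2cc3ccccc3s2)cc1Cl` reaches only a limit of this assay, giving > 100 ug/mL. Among the measured compounds shown here, the one measured step that starts from compound 2 is an at least 22-fold higher number from compound 2 to compound 3 (1.35 log units; beyond the scatter), and it ends at the limit of > 100 ug/mL in this assay, at which 1 of the 3 values shown sits, so its true size is not known beyond that.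

Compound 4 `Cc1ccc(O)c(C(=O)CC(=O)c2cc3ccccc3s2)c1` has not yet been measured. It differs from compound 2 by methyl in place of chloro on an aromatic carbon. For the measured compounds named here, no measured step exchanges chloro for methyl on this core; the only measured step adds methyl while chloro stays, and it was large and ran toward weaker inhibition of growth. That is thin ground, yet it points the same way. Compound 4 is therefore expected to give about 15 ug/mL in this assay, with a likely range from 4 ug/mL to 60 ug/mL. This expectation means a step of a 3.4-fold higher number from compound 2 to compound 4 (0.53 log units; beyond the scatter), toward weaker inhibition, with a fair chance that compound 4 also reports only a limit.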

Compound 4, concentration for 50% growth inhibition: 7.12 ug/mL
The estimate for compound 4 lay 2.1-fold (0.32 log units) above the measured number; the range from low to high includes it.
By their numbers in this assay, from the lowest: compounds 2 and 4 (each within the scatter of the next); then compound 1. At a limit, above all of these: compound 3.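

The exchange of chloro for methyl gives a 1.6-fold higher number from compound 2 to compound 4 (0.21 log units; within the scatter) in this assay, so at this place, para to a hydroxy group, chloro is not required for inhibition of growth on this scale. Among the compounds shown here, the earlier step, an at least 22-fold higher number from compound 2 to compound 3 (1.35 log units; beyond the scatter), has no counterpart here, which shows that a methyl group on this ring does not by itself carry a compound to the limit. Compound 3 remains a limit and not a number: the limit of > 100 ug/mL in this assay, at which 1 of the 4 values shown sits.

The compounds shown leave open how this place responds to other groups, such as a methoxy group, an amine, a carboxylic acid or a longer chain. They also leave open whether the hydroxy group itself matters, and why chloro and methyl read alike here.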